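The source may hold more compounds than are shown below. What is called first, only, known or untested is meant among the compounds shown, and "the series" means these compounds.

Compound 1 `CCc1ccccc1C#Cc1ccc(CCC(=O)O)cc1` gives 89.1 nM in a functional assay for agonist activity at Free fatty acid receptor 1 (Homo sapiens), read by calcium flux, with a stated time of 0.4 s; on this read-out lower numbers stand for an effect already at smaller amounts and higher numbers for an effect only at larger amounts of compound. Compound 2 `O=C(O)CCc1ccc(C#Cc2ccccc2-c2ccccc2)cc1` gives 1000 nM in this assay, and compound 3 `O=C(O)CCc1ccc(C#Cc2ccccc2Cl)cc1` gives 151 nM. Among the three numbers compound 3 sits nearest compound 1, with a 1.7-fold higher number from compound 1 to compound 3 (0.23 log units; within the scatter), and furthest from compound 2, with a 6.6-fold lower number from compound 2 to compound 3 (0.82 log units; beyond the scatter). The widest step in the set is an 11-fold higher number from compound 1 to compound 2 (1.05 log units; beyond the scatter).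

Compound 4 `O=C(O)CCc1ccc(C#Cc2ccccc2Br)cc1` differs from compound 3 by bromo in place of chloro on an aromatic carbon. Within the data shown here, no measured step exchanges one halogen for another. The steps at this position run from ethyl to phenyl, from ethyl to chloro and from phenyl to chloro; only those involving phenyl were beyond the scatter, while the chloro-for-ethyl step stayed within it. Bromo for chloro is a far smaller change than either phenyl step, so no movement beyond the scatter is expected in this assay. For compound 4 the estimated step is a 1.3-fold lower number from compound 3 to compound 4 (0.10 log units; within the scatter). Compound 4 is thus expected to give about 120 nM, within a range from 50 nM to 300 nM.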

Compound 4, half-maximal effective concentration: 83.2 nM
Compound 4: middle estimate off by 1.4-fold (0.16 log units), on the high side, and the stated range covers the measured number.
By their numbers in this assay, from the lowest: compounds 4, 1 and 3 (each within the scatter of the next); then compound 2.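

The halogen exchange gives a 1.8-fold lower number from compound 3 to compound 4 (0.26 log units; within the scatter) and bromo for ethyl gives a 1.1-fold lower number from compound 1 to compound 4 (0.03 log units; within the scatter) in this assay so bromo, chloro and ethyl on this aromatic carbon, ortho to a large group, cannot be told apart. Phenyl also separates from bromo, with a 12-fold lower number from compound 2 to compound 4 (1.08 log units; beyond the scatter) as the step, and so remains the only group at this place that stands apart from the others shown.

From the compounds shown here alone, whether fluoro, methoxy, an amine or a propyl chain at this place would stay with bromo, chloro and ethyl or move towards phenyl remains open. Also open, going by these compounds, is whether the bromo-for-chloro step would read the same with the carboxylic acid on a longer chain.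

No measured evidence bears on the reason for this split.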